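Chloro pair and the dichloro step

The compounds below may be only part of what the source reports. "The series", "measured", "known", "first", "only" and "open" are said of these compounds alone.

Measured in a functional assay on aorta (Rattus norvegicus) for inhibition; on this read-out higher numbers stand for an effect only at larger amounts of compound and lower numbers for an effect already at smaller amounts:
compound 1 `CC(C)NC1=NS(=O)(=O)c2ccc(Cl)cc2N1`: 53400 nM
compound 2 `CC(C)NC1=NS(=O)(=O)c2cc(Cl)ccc2N1`: 36300 nM

Compound 2 stands level with compound 1, as the two values lie within the usual scatter of each other. The next compound to be tested is compound 3 `CC(C)NC1=NS(=O)(=O)c2cc(Cl)c(Cl)cc2N1`. It differs from compound 2 by chloro in place of hydrogen on an aromatic carbon, ortho to a chloro group: chloro in place of hydrogen on an aromatic carbon. Going by the values given here, no pair of measured compounds shows what a single change of this kind does in this assay, so the expectation has no direct precedent. The starting point is compound 2 at 36300 nM. The expected 1.8-fold lower number from compound 2 to compound 3 (0.26 log units; within the scatter) is small, towards a lower number, and not clearly beyond the scatter. For compound 3 the estimated value is 20000 nM, with an estimated range of 7000 nM to 50000 nM.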

Compound 3, half-maximal effective concentration: 2300 nM
The estimate for compound 3 lay 8.7-fold (0.94 log units) above the measured number; measured number below the stated range.
By their numbers in this assay, from the lowest: compound 3; then compounds 2 and 1 (each within the scatter of the next).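

In this assay, adding chloro on the aromatic carbon ortho to a chloro group gives a 16-fold lower number from compound 2 to compound 3 (1.20 log units; beyond the scatter) and, from the other single-chloro compound, a 23-fold lower number from compound 1 to compound 3 (1.37 log units; beyond the scatter) as well. Compound 1 and compound 2 stand level with each other, so a single chloro in either of these two places does not separate them, whereas the two chloro groups together in compound 3 give a large step beyond the scatter from both. Nothing at hand bears on why this step is so large.

From the compounds shown here alone, whether a bromo, a methyl or a trifluoromethyl group in place of the second chloro would give a step of similar size remains open. So does whether the step would hold with a longer chain or a cyclopentyl group in place of the isopropyl group.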